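The source may hold more compounds than are shown below. What is called first, only, known or untested is meant among the compounds shown, and "the series" means these compounds.

The measured compounds:
Compound 1, `CCOc1ccc(-c2nc(N)nc(NCc3ccccc3)n2)c(CO)c1`; in a functional assay on cells for positive allosteric modulation of G-protein coupled receptor 68 (Homo sapiens), read by a luciferase reporter and cAMP accumulation, with a stated time of 30 min, at pH 6.8 and pH 8.3, in the presence of a further agent that is not named here (a higher number here means a more potent compound, by a factor of ten per unit of this negative logarithm, a lower number a less potent compound), compound 1 gives 4.37.
Compound 2, `Nc1nc(NCc2ccc(F)cc2)nc(-c2ccccc2CO)n1`; in this assay compound 2 gives 3.97.
Compound 3, `Nc1nc(NCc2ccccc2Cl)nc(-c2ccccc2CO)n1`; in this assay compound 3 gives 5.07.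

Compound 3 stands highest of the three. Compound 1 is its nearest neighbour, lower by a gap beyond the scatter, and compound 2 is furthest, lower by a larger gap. The one measured step that joins two of these compounds is a number 1.10 log units higher from compound 2 to compound 3 (beyond the scatter), which changes both the halogen and where it sits on the ring.

Compound 4, `Cc1ccccc1CNc1nc(N)nc(-c2ccccc2CO)n1`, differs from compound 3 by methyl in place of chloro on an aromatic carbon. The step from compound 2 to compound 3 bears on this only loosely: it kept the same kind of group and moved it, whereas here the place is kept and the group is swapped. For the measured compounds named here, no measured pair separates the two effects. A methyl and a chloro are both single heavy atoms without donors or acceptors, so compound 4 is expected to stay close to compound 3, with at most a modest loss.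

The expected step is therefore a number 0.27 log units lower from compound 3 to compound 4 (within the scatter), a small move downward that may lie within the scatter. For compound 4 the estimate in this assay is 4.8, with a range from 4.1 to 5.4.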

Compound 4, negative logarithm of the antagonist equilibrium constant: 4.7
Beside the measured number, compound 4's estimate is 0.10 log units above it; the measured number falls inside the stated range.
By their numbers in this assay, from the lowest: compound 2; then compound 1; then compound 4; then compound 3.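

In this assay, for the compounds shown here, with the place on the ring held fixed, the swap of chloro for methyl gives a number 0.37 log units lower from compound 3 to compound 4 (beyond the scatter), which shows for the first time that the identity of the group on this aromatic carbon, ortho to a large group, matters on its own, though modestly. The second step, a number 0.73 log units higher from compound 2 to compound 4 (beyond the scatter), shows that a number above that of compound 2 does not depend on chlorine, since the 2-methylphenyl compound also reaches it, though by less than the 2-chlorophenyl compound does. Nothing shown gives a measured property of these groups that would account for the gap between chloro and methyl.

The earlier step, a number 1.10 log units higher from compound 2 to compound 3 (beyond the scatter), and the new step from compound 2 both change the group and its place together, so how much of each step belongs to the place alone stays unresolved. From the compounds shown here alone, it also remains open how this carbon would respond to a bromo, a methoxy or a trifluoromethyl group, and whether either of the two groups seen here would keep its standing with an amine or a carboxylic acid in place of the hydroxymethyl group on the other aromatic ring.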